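The source may report more compounds than this note shows. Statements on the series, on what has been measured and on what is new or still open speak of the compounds shown alone.

Of the compounds shown here, three sharing one core have been tested in a functional assay on COLO 205 cells (Homo sapiens) for inhibition, read by sulforhodamine B assay, with a stated time of 48 h, tested at 50 uM; a lower number here means less inhibition of growth, a higher number more inhibition of growth at the concentration tested. Compound 1 `O=C1C(=O)N(CCCn2cc(COc3cc(=O)oc4ccccc34)nn2)c2ccc(F)cc21` gives 69%. Compound 2 `O=C1C(=O)N(CCCCn2cc(COc3cc(=O)oc4ccccc34)nn2)c2ccc(Cl)cc21` gives 60%. Compound 3 `O=C1C(=O)N(CCCn2cc(COc3cc(=O)oc4ccccc34)nn2)c2ccccc21` gives 75%. Within the data shown here, the one single-point step among them, hydrogen in place of fluoro on an aromatic carbon, gives a number 6 percentage points higher from compound 1 to compound 3 (within the scatter). Compound 2 stands below compound 3 by a gap beyond the scatter, while compound 1 lies within the scatter of compound 2, so these two cannot be ranked against each other.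

Compound 4 `O=C1C(=O)N(CCCCn2cc(COc3cc(=O)oc4ccccc34)nn2)c2ccc(I)cc21` has not yet been measured. It differs from compound 2 by iodo in place of chloro on an aromatic carbon. Among the measured compounds shown here, no measured pair exchanges chloro for iodo, so no step speaks to this change directly. For the measured compounds named here, the only step that touches the same aromatic carbon, from compound 1 to compound 3, swapped fluoro for hydrogen and stayed within the scatter. Taken on that evidence alone, the change from chloro to iodo is expected to produce no step beyond the scatter in this assay, in either direction; the expected step is no change at the digits printed from compound 2 to compound 4 (within the scatter). Compound 4 is therefore estimated to give 60% in this assay, with a range from 45% to 75%.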

Compound 4, percent growth inhibition at one concentration: 50%
For compound 4 the middle estimate is 10 percentage points above the measured one, within the range that was stated.
By their numbers in this assay, from the lowest: compounds 4, 2, 1 and 3 (each within the scatter of the next, the first and the last beyond it).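

In this assay, exchanging one halogen for another on this aromatic carbon gives a number 10 percentage points lower from compound 2 to compound 4 (within the scatter). Iodo, one heavy atom like the chloro it replaces and like it with no hydrogen-bond donors or acceptors, can therefore stand at this place, meta to a fused ring and para to a fused ring, without a step beyond the scatter. With the earlier exchange of fluoro for hydrogen, that makes two single changes on this carbon, each made on a different chain length, and neither step goes beyond the scatter, though nothing available here accounts for the size of either step.

On these data alone, whether a group of another kind on this carbon, such as an amine, a carboxylic acid or a methoxy group, would give a step beyond the scatter remains open. Also open, as far as these compounds go, is whether chloro and iodo would stay within the scatter of each other on the shorter chain of compound 1 and compound 3, and how these compounds would compare at concentrations other than the single one tested.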